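This account rests on a few compounds, and the source may have more. Where it says the series, first, only, none or still open, it means among the compounds named here.

Measured so far:
compound 1 `O=C(NCCCNc1nc(Nc2cncnc2)ncc1C1CC1)C1CCC1`: 3200 nM
compound 2 `O=C(CCc1ccccc1)NCCCNc1nc(Nc2cccc(F)c2)ncc1Br`: 560 nM

In an assay on isolated protein for inhibition of serine/threonine-protein kinase TBK1 (Homo sapiens) (on this read-out lower numbers stand for stronger inhibition and higher numbers for weaker inhibition), compound 1 gives 3200 nM, the higher of the two numbers. Compound 2 gives 560 nM, and the gap between the two lies beyond the scatter. These two compounds differ in several places at once, so no single change can be read from that pair. Compound 3 `Cn1ccc(Nc2ncc(C3CC3)c(NCCCNC(=O)C3CCC3)n2)n1` differs from compound 1 in one place: 1-methyl-1H-pyrazol-3-yl in place of pyrimidin-5-yl on a nitrogen on an aromatic ring. Within the data shown here, no measured pair shows this exchange, so the expectation for compound 3 is a step of a 1.3-fold lower number from compound 1 to compound 3 (0.11 log units; within the scatter), little beyond the scatter in either direction. Compound 3 is therefore expected to give about 2500 nM, between 700 nM and 9000 nM.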

Compound 3, half-maximal inhibitory concentration: > 1000 nM
Compound 3 gave a limit, no number (the forecaster's own chance of this, stated with the estimate: 10%); the middle value does not contradict the limit.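

In this assay compound 3 gives > 1000 nM, a limit and not a number. The step between compound 1 and compound 3 therefore cannot be read. The compounds shown leave open whether 1-methyl-1H-pyrazol-3-yl in place of pyrimidin-5-yl changes inhibition at all.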